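Adding a Second Methoxy: What to Expect for Compound 4

The source may hold more compounds than are shown below. What is called first, only, known or untested is meant among the compounds shown, and "the series" means these compounds.

Compound 3 `COc1ccc(-c2cn(-c3ccc(OC)cc3)nn2)cc1` is known in a functional assay on MDA-MB-231 cells (Homo sapiens) for cytotoxicity, read by MTT assay (a lower number here means a stronger inhibitor, a higher number a weaker inhibitor), only as a limit, > 100 nM. Compound 2 `COc1ccc(-c2cn(-c3ccc(OC(F)(F)F)cc3)nn2)cc1` gives 1000 nM in this assay. The change from compound 2 to compound 3 is a step that the limit leaves unreadable from compound 2 to compound 3, left unreadable because of the limit of > 100 nM in this assay, at which 1 of the 3 values shown sits. Compound 1 `COc1ccc(-n2cc(-c3ccc(OC)c(O)c3)nn2)c(OC)c1` gives only a limit, > 10000 nM, sitting at the limit of > 10000 nM in this assay, at which 1 of the 3 values shown sits. Compound 4 `COc1ccc(-c2cn(-c3ccc(OC)cc3OC)nn2)cc1` differs from compound 3 by methoxy in place of hydrogen on an aromatic carbon. No measured step resembles this change, and the single step shown has no readable size, so neither direction nor size beyond the scatter follows from it. The expected step from compound 3 to compound 4 is a step that the limit leaves unreadable from compound 3 to compound 4. Compound 4 is estimated at 3000 nM, between 500 nM and 20000 nM.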

Compound 4, half-maximal inhibitory concentration: > 10000 nM
Compound 4: no number, only a limit; the forecaster's own chance of this, stated with the estimate: 35%; at least 3.3-fold (0.52 log units) between middle value and limit.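

Compound 4, like compound 3 and compound 1, is known only as a limit, so neither step to compound 4 can be read. The compounds shown leave open whether methoxy in place of hydrogen on an aromatic carbon changes anything in this assay.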